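The compounds below may be only part of what the source reports. "The series", "measured", "known", "first", "only" and "open" are said of these compounds alone.

The study concerns three measured amides and one still to be measured, all tested in a functional assay on PANC-1 cells (Homo sapiens) for inhibition, read by MTT assay, with a stated time of 72 h; a lower number here means a stronger inhibitor, a higher number a weaker inhibitor. Compound 1 `Cc1cnc(C(=O)Nc2cccc3ccc(C)nc23)cn1` carries a 5-methylpyrazin-2-yl group on its carbonyl carbon. In this assay compound 1 gives only a limit, > 10000 nM. Compound 2 `Cc1ccc2cccc(NC(=O)c3ncccn3)c2n1` differs from compound 1 by pyrimidin-2-yl in place of 5-methylpyrazin-2-yl on a carbonyl carbon. In this assay compound 2 likewise gives only a limit, > 10000 nM. The step that the two limits leave unreadable from compound 1 to compound 2 therefore cannot be read, since both values sit at the limit of > 10000 nM in this assay, at which 2 of the 3 values shown sit. Compound 3 `Cc1cnc(C(=O)Nc2cc(OCCC3CCN(C(=O)OC(C)(C)C)CC3)cc3cccnc23)cn1` has a different core from compound 1; the difference between the two cores is not broken down here. In this assay, among the compounds with values here, compound 3 gives 9670 nM, the one number among the three values shown. Compound 4 `CC(C)(C)OC(=O)N1CCC(CCOc2cc(NC(=O)c3ncccn3)c3ncccc3c2)CC1` is the compound still to be measured; it differs from compound 3 by pyrimidin-2-yl in place of 5-methylpyrazin-2-yl on a carbonyl carbon, the same change as that made from compound 1 to compound 2, at a place described in the same words. That earlier step left no readable size to lean on. Because compound 3 already sits close to the limit of > 10000 nM in this assay, at which 2 of the 3 values shown sit, the change is expected to give a step of a 1.2-fold higher number from compound 3 to compound 4 (0.09 log units; within the scatter). Compound 4 is expected to give 12000 nM in this assay, between 5000 nM and 30000 nM, with a fair chance that only a limit is reported.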

Compound 4, half-maximal inhibitory concentration: > 10000 nM
Compound 4 was reported as a limit; the forecaster's own chance of this, stated with the estimate: 65%; the middle value is on the limit's open side.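

On the core of compound 3, pyrimidin-2-yl in place of 5-methylpyrazin-2-yl on a carbonyl carbon gives an at least 1.0-fold higher number from compound 3 to compound 4 (0.01 log units; that floor lies within the scatter) in this assay and this is only a floor, so the true step may stay within the scatter or may be larger. The change therefore ends at the same reported limit on both cores, which is all that the two pairs have in common, and the step from compound 1 to compound 2 cannot be read. This does not show that the change has the same size on the two cores, or that it has any measurable size on either, because nearly all the values stop at one limit: the limit of > 10000 nM in this assay, at which 3 of the 4 values shown sit.

The compounds shown leave open whether the step would become readable on a member of the series that gives a number clear of this limit on both sides of the change. They also leave open whether an amine or a carboxylic acid on the aromatic ring attached to the carbonyl carbon, or a longer chain on the core of compound 3, would give such a number in this assay.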